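A Third Hydroxy Group on Compound 2

The compounds below may be only part of what the source reports. "The series", "measured", "known", "first", "only" and "open" are said of these compounds alone.

Compound 1 `CCCCCCCCC(=O)NCc1ccccc1OC`: > 100000 nM, a limit
Compound 2 `CCCCCCCCC(=O)NCc1ccc(O)c(O)c1`: 630 nM
Compound 3 `CCCCCCCCC(=O)NCc1cc(OC)c(OC)c(OC)c1`: > 100000 nM, a limit
Compound 4 `CCCCCCCCC(=O)NCc1ccc(O)c(O)c1O`: not yet measured

Within the data shown here, in a functional assay with Rattus norvegicus as the target (on this read-out higher numbers stand for an effect only at larger amounts of compound and lower numbers for an effect already at smaller amounts), compound 2 gives 630 nM, the only true number among the three measured compounds. Compound 1 and compound 3 both stand at the limit of > 100000 nM in this assay, at which 2 of the 3 values shown sit.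

Compound 4 differs from compound 2 in one place: hydroxy in place of hydrogen on an aromatic carbon. It has hydroxy in place of hydrogen on an aromatic carbon. Among the measured compounds shown here, no measured pair isolates this change, so any forecast remains uncertain. A moderate shift towards higher numbers is expected in this assay. The expected step is a 4.8-fold higher number from compound 2 to compound 4 (0.68 log units; beyond the scatter). For compound 4 the estimated value is 3000 nM, with an expected range from 400 nM to 30000 nM.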

Compound 4, half-maximal effective concentration: 7640 nM
Estimate against measurement, compound 4: 2.5-fold (0.41 log units) below, and the stated range covers the measured number.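

In this assay, among these compounds, the aromatic carbon ortho to a hydroxy group and ortho to a large group proves sensitive to change: hydroxy in place of hydrogen there gives a 12-fold higher number from compound 2 to compound 4 (1.08 log units; beyond the scatter) and is the first single-place step available. Compound 4 nevertheless keeps a true number rather than falling to a limit. No measurement shown explains the size of this step. On these data alone, whether an amine or a fluorine at this carbon would give a similar step remains open. So does whether the same step would hold on a longer chain.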